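The source may hold more compounds than are shown below. What is called first, only, known or untested is meant among the compounds shown, and "the series" means these compounds.

Measurements come from a functional assay on HEK293 cells for agonist activity at G-protein coupled receptor 84 (Homo sapiens), read by calcium flux; a higher number here means that more compound is needed for the effect, a lower number that less compound is needed. Compound 1 `CCCCCc1nc(O)cc(O)n1` gives 3670 nM, the higher of the two numbers recorded; compound 3 `CCCCCCCc1cc(O)cc(O)n1` gives 1.26 nM, a far lower number, a gap well beyond the usual scatter. Compound 2 `Nc1cc(O)nc(SCCCCc2ccccc2)n1` reaches only the assay limit of > 100000 nM in this assay, a limit and not a number (the limit of > 100000 nM in this assay, at which 1 of the 3 values shown sits). Compound 4 `CC(C)CCCc1nc(O)cc(O)n1` remains to be measured; it differs from compound 1 by methyl in place of hydrogen on a saturated chain carbon bound to two saturated chain carbons. Within the data shown here, no measured pair in the set carries this change, so the size of the step is open. A modest move toward a lower number is expected for compound 4, with the expected step of a 2.0-fold lower number from compound 1 to compound 4 (0.31 log units; beyond the scatter). Compound 4 is estimated at 1800 nM in this assay, within 400 nM to 8000 nM.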

Compound 4, half-maximal effective concentration: 2110 nM
Compound 4: the middle estimate sits 1.2-fold (0.07 log units) below what was measured, within the range that was stated.
By their numbers in this assay, from the lowest: compound 3; then compounds 4 and 1 (each within the scatter of the next). At a limit, above all of these: compound 2.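

Among these compounds, the step of a 1.7-fold lower number from compound 1 to compound 4 (0.24 log units; within the scatter) in this assay is the first reading for methyl in place of hydrogen on a saturated chain carbon bound to two saturated chain carbons. This carbon therefore carries a methyl with no change that stands clear of the scatter. Nothing on hand bears on the cause of this step.

Open, going by these compounds, is how an ethyl, an amine or a carboxylic acid on this carbon would read. Also open, on these data alone, is whether a methyl here reads the same on the core of compound 3.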